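A few compounds are considered here, and "the series" means these few. Any claim that something is new, unique, unknown or untested is made for them only; others in the source may bear on it.

Measured compounds in an ADME assay on MT4 cells (Homo sapiens) for cytotoxicity, read by MTT assay, with a stated time of 5 days; a higher number here means that more compound is tolerated, a lower number that less compound is tolerated:
- compound 1 `Cc1cc(C)cc(S(=O)(=O)c2c(C(=O)N[C@H]3CCNC3)[nH]c3ccc(Cl)cc23)c1`: 10000 nM
- compound 2 `Cc1cc(C)cc(S(=O)(=O)c2c(C(=O)NC3CN(CC(N)=O)C3)[nH]c3ccc(Cl)cc23)c1`: 25500 nM
- compound 3 `Cc1cc(C)cc(S(=O)(=O)c2c(C(=O)NC3CN(Cc4n[nH]c(=O)n4C)C3)[nH]c3ccc(Cl)cc23)c1`: 25200 nM

Compound 1 gives the lowest number of the three in this assay; the nearest is compound 3, the furthest compound 2, both separated from it by steps beyond the scatter.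

Compound 4 `Cc1cc(C)cc(S(=O)(=O)c2c(C(=O)NS(=O)(=O)c3ccc(F)cc3F)[nH]c3ccc(Cl)cc23)c1` has not been measured. The change from compound 1 is (2,4-difluorophenyl)sulfonyl in place of pyrrolidin-3-yl on an amide-type nitrogen.

Among the measured compounds shown here, two measured steps bear on it, since both also replace the pyrrolidin-3-yl on the amide-type nitrogen: a 2.6-fold higher number from compound 1 to compound 2 (0.41 log units; beyond the scatter) and a 2.5-fold higher number from compound 1 to compound 3 (0.40 log units; beyond the scatter). Both are modest and point upward, and the further change between compound 2 and compound 3, a 1.0-fold lower number from compound 2 to compound 3 (0.01 log units; within the scatter), stays within the scatter. The group entering in compound 4 differs in kind from those two, so the measured steps give only a loose guide. An upward step of similar, modest size is expected, a 1.6-fold higher number from compound 1 to compound 4 (0.20 log units; within the scatter), with wide uncertainty. For compound 4 the estimate in this assay is 16000 nM, in the range 5000 nM to 50000 nM.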

Compound 4, half-maximal cytotoxic concentration: 121000 nM
Beside the measured number, compound 4's estimate is 7.6-fold (0.88 log units) below it; measured number outside the range, above it.
By their numbers in this assay, from the lowest: compound 1; then compounds 3 and 2 (each within the scatter of the next); then compound 4.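

Notes on the amide-type nitrogen in this assay: compounds 2 and 3 suggested a modest rise with little difference between their groups, but (2,4-difluorophenyl)sulfonyl in place of pyrrolidin-3-yl gives a 12-fold higher number from compound 1 to compound 4 (1.08 log units; beyond the scatter) and so shows that this position can carry a large change. The new group also stands clear of both earlier replacements, with a 4.7-fold higher number from compound 2 to compound 4 (0.68 log units; beyond the scatter) and a 4.8-fold higher number from compound 3 to compound 4 (0.68 log units; beyond the scatter) in the same assay, so the level shared by compounds 2 and 3 is no ceiling for this position. Nothing available accounts for the size of this rise.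

From the compounds shown here alone, compound 4 changes the sulfonyl link and the difluorophenyl ring together, so which of them carries the step stays open. A methylsulfonyl or an unsubstituted phenylsulfonyl group on the same nitrogen would separate the two.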